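Butoxy to acetoxy: what to expect of compound 4

A few compounds are considered here, and "the series" means these few. Any claim that something is new, unique, unknown or untested is made for them only; others in the source may bear on it.

compound 1 `CC(C(=O)NCc1ccc(C(F)(F)F)nc1NCc1ccccc1)c1ccc(NS(C)(=O)=O)c(F)c1`: 203 nM
compound 2 `CCCCN(C)c1nc(C(F)(F)F)ccc1CNC(=O)C(C)c1ccc(NS(C)(=O)=O)c(F)c1`: 21.3 nM
compound 3 `CCCCOC1CCN(c2nc(C(F)(F)F)ccc2CNC(=O)C(C)c2ccc(NS(C)(=O)=O)c(F)c2)CC1`: 28.2 nM

In a functional assay on CHO-K1 cells for antagonist activity at transient receptor potential cation channel subfamily V member 1 (Homo sapiens), read by FLIPR (on this read-out lower numbers stand for stronger inhibition and higher numbers for weaker inhibition), compound 3 stands second highest of the three numbers. The step of a 1.3-fold higher number from compound 2 to compound 3 (0.12 log units; within the scatter) lies within the scatter, whereas a 7.2-fold lower number from compound 1 to compound 3 (0.86 log units; beyond the scatter) and a 9.5-fold lower number from compound 1 to compound 2 (0.98 log units; beyond the scatter) are beyond it. Compound 4 `CC(=O)OC1CCN(c2nc(C(F)(F)F)ccc2CNC(=O)C(C)c2ccc(NS(C)(=O)=O)c(F)c2)CC1` differs from compound 3 by acetyl in place of butyl on an oxygen on a saturated carbon. Going by the values given here, none of the measured steps alters that same position; the only one touching the neighbouring region, a 1.3-fold higher number from compound 2 to compound 3 (0.12 log units; within the scatter), exchanged the whole substituent on the aromatic carbon and stayed within the scatter. The step in this assay is therefore expected to be small, a 1.6-fold higher number from compound 3 to compound 4 (0.20 log units; within the scatter), in no direction beyond the scatter. Compound 4 is estimated at 45 nM, between 15 nM and 150 nM.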

Compound 4, half-maximal inhibitory concentration: 139 nM
Beside the measured number, compound 4's estimate is 3.1-fold (0.49 log units) below it, within the range that was stated.
By their numbers in this assay, from the lowest: compounds 2 and 3 (each within the scatter of the next); then compounds 4 and 1 (each within the scatter of the next).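

In this assay, going by these compounds alone, acetyl in place of butyl on an oxygen on a saturated carbon gives a 4.9-fold higher number from compound 3 to compound 4 (0.69 log units; beyond the scatter) and so shows that this position, unchanged in the earlier steps, responds to substitution. With 4-acetoxypiperidin-1-yl on the aromatic carbon the comparison with butyl(methyl)amino gives a 6.5-fold higher number from compound 2 to compound 4 (0.81 log units; beyond the scatter) while the comparison with benzylamino gives a 1.5-fold lower number from compound 1 to compound 4 (0.16 log units; within the scatter) and thus only a difference within the scatter. No measurement at hand accounts for the step.

The compounds shown leave open whether the carbonyl or the shorter chain governs the result. From the compounds shown here alone, how a hydroxyl, a methoxy group or an acetamide would read on the same saturated carbon also remains open.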